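A few compounds are considered here, and "the series" means these few. Any claim that something is new, unique, unknown or untested is made for them only; others in the source may bear on it.

Measured compounds:
compound 1, `Cc1ccc(-n2cc(CN3C(=O)C[C@@H]4CC[C@@]3(C)C4(C)C)nn2)cc1`: in a functional assay on PANC-1 cells (Homo sapiens) for inhibition, read by MTT assay, with a stated time of 24 h (a lower number here means a stronger inhibitor, a higher number a weaker inhibitor), compound 1 gives 270 nM
compound 2, `CC1(C)[C@H]2CC[C@]1(C)N(Cc1cn(-c3ccccc3)nn1)C(=O)C2`: in this assay compound 2 gives 160 nM
compound 3, `CC1(C)[C@H]2CC[C@]1(C)N(Cc1cn(-c3cccc(Br)c3)nn1)C(=O)C2`: in this assay compound 3 gives 90 nM

Compound 3 holds the lowest of the three numbers. Its nearest neighbour sits within the scatter: a 1.8-fold lower number from compound 2 to compound 3 (0.25 log units; within the scatter). Its furthest lies beyond it: a 3.0-fold lower number from compound 1 to compound 3 (0.48 log units; beyond the scatter). On these three numbers alone compound 3 cannot be called the strongest, since one of its gaps stays within the scatter.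

Compound 4, `CC1(C)[C@H]2CC[C@]1(C)N(Cc1cn(-c3cccc(C#N)c3)nn1)C(=O)C2`, differs from compound 3 in one place: cyano in place of bromo on an aromatic carbon. Among the measured compounds shown here, no measured pair exchanges bromo for cyano. The steps that touch the same aromatic carbon are a 1.8-fold lower number from compound 2 to compound 3 (0.25 log units; within the scatter) and a 3.0-fold lower number from compound 1 to compound 3 (0.48 log units; beyond the scatter); both run toward lower numbers once bromo is present, and one of them is within the scatter, the other modest. Nothing here tells how cyano behaves at that position, so the expected step from compound 3 to compound 4 is one within the scatter, a 1.2-fold higher number from compound 3 to compound 4 (0.09 log units; within the scatter), with no direction asserted. The estimate for compound 4 in this assay is therefore 110 nM, expected to fall between 45 nM and 270 nM.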

Compound 4, half-maximal inhibitory concentration: 260 nM
Estimate against measurement, compound 4: 2.4-fold (0.37 log units) below, and the stated range covers the measured number.
By their numbers in this assay, from the lowest: compounds 3, 2, 4 and 1 (each within the scatter of the next, the first and the last beyond it).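

In this assay, among the compounds shown here, the exchange of 3-bromophenyl for 3-cyanophenyl is the first step confined to this aromatic carbon that lies beyond the scatter: a 2.9-fold higher number from compound 3 to compound 4 (0.46 log units; beyond the scatter). The gain seen with bromo does not carry over to cyano, since the comparison with hydrogen on this carbon reads a 1.6-fold higher number from compound 2 to compound 4 (0.21 log units; within the scatter) and the comparison with the 4-methylphenyl group reads a 1.0-fold lower number from compound 1 to compound 4 (0.02 log units; within the scatter), so neither step separates compound 4 from its partner. No measured evidence accounts for the gap between bromo and cyano at this carbon.

Still open, on these data alone, is whether the low number of compound 3 is particular to bromo or also holds for chloro or iodo. As far as these compounds go, the response to an amine or a carboxylic acid on this carbon, and to bromo on other carbons of the ring, also remains open.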